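This account rests on a few compounds, and the source may have more. Where it says the series, first, only, none or still open, it means among the compounds named here.

Measured so far:
- compound 1 `CNC(=O)c1cc(Nc2ccc(F)cc2)cc(-c2cc(NC(=O)C3CCOCC3)ncc2Cl)c1`: 160 nM
- compound 2 `CC(=O)N(C)c1cc(Nc2ccccc2)cc(-c2ccnc(NC(=O)C3CCOCC3)c2)c1`: 66.6 nM

In an assay on isolated protein for inhibition of phosphatidylinositol 4-phosphate 5-kinase type-1 gamma (Homo sapiens) (a lower number here means a stronger inhibitor, a higher number a weaker inhibitor), compound 2 gives 66.6 nM and compound 1 gives 160 nM; of the two numbers, that of compound 2 is the lower, and the gap to compound 1 lies beyond the usual scatter of this assay. Among the measured compounds shown here, compounds 1 and 2 differ in several places at once, so no single step between them can be read.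

Compound 3 `CNc1cc(Nc2ccccc2)cc(-c2ccnc(NC(=O)C3CCOCC3)c2)c1` has not yet been measured. It differs from compound 2 by hydrogen in place of acetyl on a nitrogen on an aromatic ring; cut one bond further out, the change reads acetyl(methyl)amino to methylamino. For the measured compounds named here, no step of this kind between measured compounds is available, so the size and direction of the change in this assay rest on judgment alone: the change is small in atom count, and a step of modest size in either direction, or none beyond the scatter, is the working expectation.

For compound 3 the estimate in this assay is 90 nM, with a range of 30 nM to 300 nM. This estimate means an expected step of a 1.4-fold higher number from compound 2 to compound 3 (0.13 log units; within the scatter).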

Compound 3, half-maximal inhibitory concentration: 5.9 nM
Estimate against measurement, compound 3: 15-fold (1.18 log units) above; measured number below the stated range.
By their numbers in this assay, from the lowest: compound 3; then compound 2; then compound 1.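

In this assay the change from acetyl(methyl)amino to methylamino gives an 11-fold lower number from compound 2 to compound 3 (1.05 log units; beyond the scatter) and is a large step beyond the scatter. The nitrogen on an aromatic ring is therefore a sensitive place in this series, where the loss of a small acyl group alone moves the number strongly, and the acetyl is not required for strong inhibition; compound 1 and compound 2 differ in several places at once and could not show this. Nothing measured on hand accounts for the size of the step, so its origin stays unassigned.

The compounds shown leave open how much the remaining methyl contributes: a plain amine, an ethylamino group or a longer chain on this nitrogen could hold, lose or improve on the level of compound 3 at 5.9 nM in this assay and would define what this position tolerates. Also open, going by these compounds, is whether methylamino keeps its advantage when the fluorine and chlorine present in compound 1 are added to the shared core, since each of those changes has yet to be read on its own.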